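Swapping fluoro and methoxy places on the benzyl ring

This account rests on a few compounds, and the source may have more. Where it says the series, first, only, none or still open, it means among the compounds named here.

Compound 1, `COc1cc(F)c(CN2C(=O)N(c3ccc(OC)c(OC)c3)S(=O)(=O)c3ccccc32)c(Cl)c1`, gives 0.398 nM in an assay on isolated protein for displacement of a labelled ligand from Orexin/Hypocretin receptor type 1 (Homo sapiens), with a stated time of 90 min; on this read-out lower numbers stand for stronger inhibition and higher numbers for weaker inhibition.
Compound 2, `COc1cc(F)c(CN2C(=O)N(c3ccc(OC)c(OC)c3)S(=O)(=O)c3ccccc32)c(F)c1`, gives 2 nM in this assay.

Of these two numbers, compound 2 stands highest, separated from compound 1 by a 5.0-fold higher number from compound 1 to compound 2 (0.70 log units; beyond the scatter). Compound 3, `COc1ccc(N2C(=O)N(Cc3c(F)cc(F)cc3OC)c3ccccc3S2(=O)=O)cc1OC`, differs from compound 2 by 2,4-difluoro-6-methoxyphenyl in place of 2,6-difluoro-4-methoxyphenyl on a saturated chain carbon bound to an amide-type nitrogen in a ring. Within the data shown here, the one measured step exchanges chloro for fluoro at a fixed place and does not bear on moving groups around the ring, so the data give no direct guide to this change. With nothing to point either way, only a modest shift is expected, and the range is kept wide. Compound 3 is expected to give 4 nM, with a range from 1 nM to 16 nM. The expected step is a 2.0-fold higher number from compound 2 to compound 3 (0.30 log units; within the scatter).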

Compound 3, inhibition constant: 63.1 nM
Estimate against measurement, compound 3: 16-fold (1.20 log units) below; measured number above the stated range.
By their numbers in this assay, from the lowest: compound 1; then compound 2; then compound 3.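

The arrangement of the same atoms on this ring matters: with no atom gained or lost, the switch to 2,4-difluoro-6-methoxyphenyl gives a 32-fold higher number from compound 2 to compound 3 (1.50 log units; beyond the scatter) at the saturated chain carbon bound to an amide-type nitrogen in a ring. Against the 2-chloro-6-fluoro-4-methoxyphenyl group, the same arrangement gives a 160-fold higher number from compound 1 to compound 3 (2.20 log units; beyond the scatter) and leaves compound 3 the weakest of the series. Nothing available explains why this rearrangement costs so much.

Still open, going by these compounds, is how a 2,6-dichloro-4-methoxyphenyl group would compare. The effect of a hydroxy or ethoxy group in place of the methoxy is also unknown.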